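The compounds below may be only part of what the source reports. "The series", "measured", "known", "first", "only" and "open" are said of these compounds alone.

Measured compounds:
compound 1 `O=C(O)c1cc(-n2c(-c3ccccc3)cc3c2CCCC3)ccc1O` — >= 60% in a functional assay on the whole organism (strain Wistar) for inhibition, with Rattus norvegicus as the target, read by paw edema, with stated times of 30 min and 3 h, at a dose of 200 mg/kg by the oral route; on this read-out higher numbers stand for more inhibition at the one dose given (going by the name of the read-out) and lower numbers for less inhibition
compound 2 `O=C(O)c1cc(-n2c(-c3ccccc3)cc3c2CCCC3)cc(Cl)c1O` — 0% in this assay

Compound 1 stands at a limit of the assay rather than at a number: in this assay compound 1 gives >= 60%, which is a limit, as recorded in the limit of >= 60% in this assay, at which 1 of the 2 values shown sits. Among the compounds with values here, compound 2 is the only other measured point, and the one measured step runs a number at least 60 percentage points lower from compound 1 to compound 2 (beyond the scatter). That step places a chloro on the ring carrying the acid; it says nothing direct about the other ring.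

The unmeasured compound 3 `O=C(O)c1cc(-n2c(-c3ccc(F)cc3)cc3c2CCCC3)ccc1O` differs from compound 1 as follows: fluoro in place of hydrogen on an aromatic carbon. Within the data shown here, the change sits on the phenyl rather than on the ring where the chloro of compound 2 entered, so the large drop seen from compound 1 to compound 2 does not bear on it closely; there is no measured step for a change on the phenyl. The expectation is therefore a step of no clear size beyond the scatter, and the estimate for the step is a number at least 5 percentage points lower from compound 1 to compound 3 (that floor lies within the scatter). For compound 3 the value expected in this assay is 55%, with a range from 25% to 75%.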

Compound 3, a percentage reported as inhibition, in the whole organism at one dose (the size of the read-out at that dose, not a potency): >= 60%
Compound 3: a limit, no number; the forecaster's own chance of this, stated with the estimate: 40%; middle value at least 5 percentage points from the limit.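

Compound 1 and compound 3 yield no readable step for the change from phenyl to 4-fluorophenyl, because both values are limits rather than numbers: the limit of >= 60% in this assay, at which 2 of the 3 values shown sit.

The compounds shown leave open whether fluoro in place of hydrogen on this ring changes the inhibition seen in this assay at all, or by how much.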